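The compounds below may be only part of what the source reports. "The series", "measured", "known", "first", "only" and "open" are said of these compounds alone.

Compound 1 `COC1=C(C)C(=O)/C(=C(O)/C=C/c2ccc(Br)cc2)C(=O)C1(C)C`, compound 2 `COC1=C(C)C(=O)/C(=C(O)/C=C/c2ccccc2OC)C(=O)C1(C)C` and compound 3 `COC1=C(C)C(=O)/C(=C(O)/C=C/c2c(C)cccc2C)C(=O)C1(C)C` share one core and differ only in the aryl group at the end of the chain. In a functional assay on A549 cells (Homo sapiens) for cytotoxicity (a higher number here means that more compound is needed for the effect, a lower number that less compound is needed), compound 1 gives 1.4 ug/mL. In this assay compound 2 gives 2.4 ug/mL, and compound 3 gives 8.3 ug/mL. Compound 2 thus holds the second highest of the three numbers; its nearest neighbour is compound 1 a 1.7-fold higher number from compound 1 to compound 2 (0.23 log units; within the scatter) and its furthest is compound 3 a 3.5-fold higher number from compound 2 to compound 3 (0.54 log units; beyond the scatter). The widest step of the set is a 5.9-fold higher number from compound 1 to compound 3 (0.77 log units; beyond the scatter).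

Compound 4 `COC1=C(C)C(=O)/C(=C(O)/C=C/c2cc(C)cc(C)c2)C(=O)C1(C)C` is not yet measured. From compound 2 it differs as 3,5-dimethylphenyl in place of 2-methoxyphenyl on a double-bonded chain carbon bound to a double-bonded chain carbon. The step that bears most directly on it is a 3.5-fold higher number from compound 2 to compound 3 (0.54 log units; beyond the scatter), where a dimethylphenyl, though a differently substituted one, also replaced the 2-methoxyphenyl; a 5.9-fold higher number from compound 1 to compound 3 (0.77 log units; beyond the scatter) points the same way. By contrast a 1.7-fold higher number from compound 1 to compound 2 (0.23 log units; within the scatter) was within the scatter and shows that not every change of aryl moves the number. Within the data shown here, a modest higher number in this assay is therefore expected for compound 4, a 2.1-fold higher number from compound 2 to compound 4 (0.32 log units; beyond the scatter), with the range kept wide because the 3,5-dimethylphenyl has no measured counterpart of its own. Compound 4 is expected to give 5 ug/mL in this assay, between 2 ug/mL and 12 ug/mL.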

Compound 4, concentration for half-maximal effect: 4.3 ug/mL
For compound 4 the middle estimate is 1.2-fold (0.07 log units) above the measured one; the measured number falls inside the stated range.
By their numbers in this assay, from the lowest: compounds 1, 2, 4 and 3 (each within the scatter of the next, the first and the last beyond it).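

At this place, on a double-bonded chain carbon bound to a double-bonded chain carbon, a 1.8-fold higher number from compound 2 to compound 4 (0.25 log units; within the scatter) shows that in this assay 3,5-dimethylphenyl, which has the same count of heavy atoms as 2-methoxyphenyl but no oxygen and no hydrogen-bond acceptor, can replace it without a change beyond the scatter. The comparison of the two dimethylphenyl groups, a 1.9-fold lower number from compound 3 to compound 4 (0.29 log units; within the scatter), does not separate them, so a 3.5-fold higher number from compound 2 to compound 3 (0.54 log units; beyond the scatter) cannot by itself be read as a general result of replacing 2-methoxyphenyl with a dimethylphenyl. The 4-bromophenyl compound remains clearly apart from this new compound, with a 3.1-fold higher number from compound 1 to compound 4 (0.49 log units; beyond the scatter), and no supporting data are available to explain any of these steps.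

The compounds shown leave open how the number responds when the aryl group carries an amine or a carboxylic acid, since all four end groups are phenyl rings bearing only bromine, methoxy or methyl. They also leave open whether a pyridine ring or a longer alkyl chain could stand at this place, and whether chlorine would track with bromine.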